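The source may report more compounds than this note shows. Statements on the series, on what has been measured and on what is new or still open speak of the compounds shown alone.

Measured so far in an ADME assay on TZM cells (Homo sapiens) for cytotoxicity, read by MTT assay, with a stated time of 48 h; on this read-out lower numbers stand for higher toxicity in this test and higher numbers for lower toxicity in this test:
compound 1, `O=C1CSC(c2c(F)cccc2Cl)N1C(=O)Nc1ccncc1`, 105000 nM
compound 2, `O=C1CSC(c2c(Cl)cccc2Cl)N1C(=O)Nc1ccncc1`, 170000 nM
compound 3, `O=C1CSC(c2c(F)cccc2Cl)N1c1ccccn1`, 153000 nM

Compound 1 and compound 2 differ in one place: chloro in place of fluoro on an aromatic carbon. The step in this assay was a 1.6-fold higher number from compound 1 to compound 2 (0.21 log units; within the scatter). Compound 3 carries another core; the difference between the core of compound 1 and the core of compound 3 is not broken down here. Compound 4, `O=C1CSC(c2c(Cl)cccc2Cl)N1c1ccccn1`, is still to be measured in this assay. It differs from compound 3 by chloro in place of fluoro on an aromatic carbon, which is the same change, at the same place, as that from compound 1 to compound 2; among the compounds shown it occurs two times in all. For compound 4 the step from compound 3 is expected to be a 1.4-fold higher number from compound 3 to compound 4 (0.16 log units; within the scatter), which rests on the earlier step of a 1.6-fold higher number from compound 1 to compound 2 (0.21 log units; within the scatter). Compound 4 is therefore estimated at 220000 nM in this assay, within an expected range from 110000 nM to 440000 nM.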

Compound 4, half-maximal cytotoxic concentration: 149000 nM
Compound 4: the middle estimate sits 1.5-fold (0.17 log units) above what was measured; the measured number falls inside the stated range.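

In this assay, chloro in place of fluoro on the aromatic carbon gives a 1.0-fold lower number from compound 3 to compound 4 (0.01 log units; within the scatter). Set beside the earlier step, the change behaves alike on both cores: the same change on two cores in this assay, a 1.6-fold higher number (0.21 log units; within the scatter) from compound 1 to compound 2 and a 1.0-fold lower number (0.01 log units; within the scatter) from compound 3 to compound 4, 1.7-fold (0.22 log units) apart, within the scatter of two such steps This shows a change that stays within the scatter on the two cores shown, with no sign that the core alters it, but it rests on only two pairs in a single cytotoxicity test and does not show that the change would stay this small on another core or in another test.

From the compounds shown here alone, whether an amine or a methoxy group on that aromatic carbon would move the number beyond the scatter stays open. Also open, going by these compounds, is how far the core itself matters, since the cores of compound 1 and compound 3 differ in more than one place.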